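From 2-chlorobenzyl to 4-chlorobenzyl: working notes on compound 3

The source may hold more compounds than are shown below. What is called first, only, known or untested is meant among the compounds shown, and "the series" means these compounds.

Measured in a functional assay on NIH3T3 cells (Mus musculus); on this read-out lower numbers stand for an effect already at smaller amounts and higher numbers for an effect only at larger amounts of compound:
- compound 1 `CSCC[C@H](NC(=O)c1ccc(NCc2cncn2Cc2ccc(C)cc2)cc1-c1ccccc1)C(=O)O` gives > 10 uM as a limit
- compound 2 `CSCC[C@H](NC(=O)c1ccc(NCc2cncn2Cc2ccccc2Cl)cc1-c1ccccc1)C(=O)O` gives > 10 uM as a limit

Within the data shown here, compound 2 stands only at a limit and not at a number, and the one other value is a limit too. The evidence so far is the limit of > 10 uM in this assay, at which 2 of the 2 values shown sit, and nothing finer. The next compound, compound 3 `CSCC[C@H](NC(=O)c1ccc(NCc2cncn2Cc2ccc(Cl)cc2)cc1-c1ccccc1)C(=O)O`, has the same atoms as compound 2, joined differently: 4-chlorophenyl in place of 2-chlorophenyl on a saturated chain carbon bound to an aromatic nitrogen, with 4-chlorophenyl in place of 2-chlorophenyl on a saturated chain carbon bound to an aromatic nitrogen.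

Among the measured compounds shown here, the only measured step bearing on this change is a step that the two limits leave unreadable from compound 1 to compound 2 and it also falls on this group. Resting on compound 2 and on (the limit of > 10 uM in this assay, at which 2 of the 2 values shown sit), the expectation is no step beyond the usual scatter in this assay, and no direction can be given. The estimated change is a step that the limit leaves unreadable from compound 2 to compound 3 and a further limit is the likeliest report. For compound 3 the expected value is 20 uM with an estimated range from 8 uM to 60 uM in this series.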

Compound 3, concentration for half-maximal effect: > 10 uM
Compound 3 was reported as a limit; the forecaster's own chance of this, stated with the estimate: 85%; the middle value does not contradict the limit.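

In this assay compound 3 gives > 10 uM, again a limit. No step can be read among compound 1, compound 2 and compound 3: the limit of > 10 uM in this assay, at which 3 of the 3 values shown sit.

The compounds shown leave open what number lies behind each limit, and whether 4-methylphenyl, 2-chlorophenyl and 4-chlorophenyl differ in effect at all.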